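Thiophen-2-yl to Pyridin-3-yl: Effect on Topoisomerase 1 Inhibition

The compounds below may be only part of what the source reports. "The series", "measured", "known", "first", "only" and "open" are said of these compounds alone.

Three compounds have been measured in an assay on isolated protein for inhibition of DNA topoisomerase 1 (Homo sapiens), with a stated time of 30 min, tested at 100 uM; a lower number here means a weaker effect, a higher number a stronger effect of the compound at the concentration tested:

compound 1 `Oc1cccc(-c2cc(-c3ccc(Cl)cc3)nc(-c3cccs3)c2)c1`: 15.1%
compound 2 `Oc1cccc(-c2cc(-c3ccc(Cl)cc3)nc(-c3cccnc3)c2)c1`: 2.8%
compound 3 `Oc1ccc(-c2cc(-c3cccc(Cl)c3)nc(-c3cccs3)c2)cc1`: 52.4%

Compound 3 gives the highest number of the three, beyond the scatter relative to both compound 1 and compound 2. Compound 1 and compound 3 contain the same atoms joined differently; the difference between the two cores is not broken down here. From compound 1 to compound 2 the change is pyridin-3-yl in place of thiophen-2-yl on an aromatic carbon, and it gives a number 12.3 percentage points lower from compound 1 to compound 2 (beyond the scatter).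

Compound 4 `Oc1ccc(-c2cc(-c3cccnc3)nc(-c3cccc(Cl)c3)c2)cc1` follows from compound 3 by pyridin-3-yl in place of thiophen-2-yl on an aromatic carbon. This is the same kind of change, but the surroundings differ: here the place is meta to a 3-chlorophenyl group and meta to a 4-hydroxyphenyl group, whereas in compound 1 it is meta to a 3-hydroxyphenyl group and meta to a 4-chlorophenyl group. Within the data shown here, a step of a number 12.4 percentage points lower from compound 3 to compound 4 (beyond the scatter) is expected from compound 3 to compound 4, resting on the single earlier instance, a number 12.3 percentage points lower from compound 1 to compound 2 (beyond the scatter), with wide uncertainty since the surroundings are not identical. Compound 4 is thus estimated at 40%, between 20% and 58%.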

Compound 4, a percentage reported as inhibition, at one concentration (the size of the read-out at that concentration, not a potency): 55.2%
Beside the measured number, compound 4's estimate is 15.2 percentage points below it; measured number inside the range.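

On the core of compound 3, pyridin-3-yl in place of thiophen-2-yl gives a number 2.8 percentage points higher from compound 3 to compound 4 (within the scatter), so the loss seen on the core of compound 1 does not recur there. The change therefore does not carry over as a fixed step between these two cores: the same change on two cores in this assay, a number 12.3 percentage points lower (beyond the scatter) from compound 1 to compound 2 and a number 2.8 percentage points higher (within the scatter) from compound 3 to compound 4, 15.1 percentage points apart, beyond the scatter of two such steps. Among these compounds, with only one pair on each core, this does not show what about the cores sets the two steps apart, nor how the change would behave on any further core.

The compounds shown leave open what an amine or a carboxylic acid on the pyridin-3-yl ring would do. Going by these compounds, it also remains open how a methoxy group in place of the hydroxyl would affect either core.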